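The compounds below may be only part of what the source reports. "The series", "measured", "known", "first", "only" and "open" are said of these compounds alone.

Of the compounds shown here, two of one family have been measured so far. Compound 1 `N=C(N)c1ccc(-c2ccc(-c3cc(Cl)cc(Cl)c3)s2)cc1` gives 2420 nM in a functional assay on OVCAR-8 cells (Homo sapiens) for inhibition, read by sulforhodamine B assay, with a stated time of 48 h; a higher number here means a weaker inhibitor of growth, a lower number a stronger inhibitor of growth. Compound 2 `COc1cc(OC)cc(-c2ccc(-c3ccc(C(=N)N)c(F)c3)s2)c1` gives 1200 nM in this assay, the lowest of the two numbers; its nearest neighbour is compound 1, whose number lies within the scatter, so no order between the two can be claimed. Compound 3 `COc1cc(OC)cc(-c2ccc(-c3ccc(C(=N)N)cc3)s2)c1` has not yet been measured in this assay. It differs from compound 2 in one place: hydrogen in place of fluoro on an aromatic carbon. Among the measured compounds shown here, no measured pair in this set shows the effect of such a change, so the size of the step can only be expected, not read off. In this assay a step of a 1.3-fold higher number from compound 2 to compound 3 (0.10 log units; within the scatter) is expected, meaning none beyond the scatter in either direction. Compound 3 is accordingly estimated at 1500 nM, with a range from 600 nM to 4000 nM.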

Compound 3, concentration for 50% growth inhibition: 2480 nM
Estimate against measurement, compound 3: 1.7-fold (0.22 log units) below, and the stated range covers the measured number.
By their numbers in this assay, from the lowest: compounds 2, 1 and 3 (each within the scatter of the next, the first and the last beyond it).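

Hydrogen in place of fluoro on the aromatic carbon ortho to a group of 3 heavy atoms gives a 2.1-fold higher number from compound 2 to compound 3 (0.32 log units; beyond the scatter) in this assay, so this position is not indifferent to the change. Among the compounds shown here, the step is modest and lies only slightly beyond the scatter, but it is the first reading of this change in the family, and the fluoro compound carries the lower number. No evidence is available on what lies behind the step.

The compounds shown leave open whether the same change would give a similar step on the core of compound 1. They also do not tell how a larger or different group at this position, such as a nitrile, a hydroxyl or a trifluoromethyl, would compare with fluoro.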